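Pyridin-2-yl for 2-Chlorophenyl: What to Expect

The compounds below may be only part of what the source reports. "The series", "measured", "known", "first", "only" and "open" are said of these compounds alone.

In a functional assay on HepG2 cells (Homo sapiens) for antiproliferative activity, read by MTT assay, with a stated time of 48 h (on this read-out higher numbers stand for weaker inhibition and lower numbers for stronger inhibition), compound 1 `COc1cccc(N2CCN(Cn3nc(-c4ccc5c(c4)OCCO5)oc3=S)CC2)c1` gives 21400 nM, while compound 2 `S=c1oc(-c2ccc3c(c2)OCCO3)nn1CN1CCN(c2ccccc2Cl)CC1` gives 11400 nM; the two numbers sit within the scatter of each other, as the step of a 1.9-fold lower number from compound 1 to compound 2 (0.27 log units; within the scatter) shows. Compound 3 `S=c1oc(-c2ccc3c(c2)OCCO3)nn1CN1CCN(c2ccccn2)CC1` differs from compound 2 by one change: pyridin-2-yl in place of 2-chlorophenyl on an amine nitrogen in a ring. Among the compounds with values here, the only measured step that also exchanges the group on this ring nitrogen, a 1.9-fold lower number from compound 1 to compound 2 (0.27 log units; within the scatter), was too small to count. A similar outcome is therefore expected, with the step of a 1.2-fold higher number from compound 2 to compound 3 (0.09 log units; within the scatter) not beyond the scatter. Compound 3 is estimated at 14000 nM, with a range from 5000 nM to 40000 nM.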

Compound 3, half-maximal inhibitory concentration: 11400 nM
For compound 3 the middle estimate is 1.2-fold (0.09 log units) above the measured one; measured number inside the range.
By their numbers in this assay, from the lowest: compounds 2, 3 and 1 (each within the scatter of the next).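

In this assay, the new ring on this amine nitrogen gives no change at the digits printed from compound 2 to compound 3 (within the scatter) and also a 1.9-fold lower number from compound 1 to compound 3 (0.27 log units; within the scatter) as its second step. All three aromatic rings tried at this position therefore stay within the scatter of one another, even though pyridin-2-yl brings a hydrogen-bond acceptor that 2-chlorophenyl lacks. Nothing measured here offers an explanation for this result.

Still open, going by these compounds, is whether a group without an aromatic ring, such as a longer alkyl chain or a carboxylic acid, would give a step beyond the scatter at this position.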